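The source may report more compounds than this note shows. Statements on the series, on what has been measured and on what is new or still open speak of the compounds shown alone.

Series notes. Compound 1 `Cc1nc(S(C)(=O)=O)ccc1Oc1ncnc(OC2CCN(C(=O)O[C@H](C)CF)CC2)c1F` is the reference point: in a functional assay on isolated protein for inhibition of Glucose-dependent insulinotropic receptor (Homo sapiens), read by HTRF and cAMP accumulation (a lower number here means that less compound is needed, a higher number that more compound is needed for the effect), compound 1 gives 196 nM, the highest of the three numbers in hand. Compound 2 `Cc1nc(S(C)(=O)=O)ccc1Oc1ncnc(OC2CCN(C(=O)C(F)(F)F)CC2)c1F` gives 151 nM and compound 3 `Cc1nc(S(C)(=O)=O)ccc1Oc1ncnc(OC2CCN(C(=O)C(C)(F)F)CC2)c1F` gives 37 nM. Compound 4 `CCC(F)(F)C(=O)N1CCC(Oc2ncnc(Oc3ccc(S(C)(=O)=O)nc3C)c2F)CC1` is not yet measured; relative to compound 1 the change is a group of 5 heavy atoms (3 carbon, 2 fluorine; no ring) in place of a group of 5 heavy atoms (3 carbon, 1 oxygen, 1 fluorine; no ring), on a carbonyl carbon. For the measured compounds named here, two measured steps bear on it: a 1.3-fold lower number from compound 1 to compound 2 (0.11 log units; within the scatter), and a 5.3-fold lower number from compound 1 to compound 3 (0.72 log units; beyond the scatter). The 1,1-difluoropropyl entering compound 4 most resembles the group present in compound 3, so a step of roughly the size seen from compound 1 to compound 3 is expected, toward a lower number. For compound 4 the expected step is a 4.4-fold lower number from compound 1 to compound 4 (0.64 log units; beyond the scatter). The estimate for compound 4 is 45 nM, with a range of 18 nM to 110 nM.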

Compound 4, half-maximal effective concentration: 17.4 nM
Compound 4: the middle estimate sits 2.6-fold (0.41 log units) above what was measured, outside the stated range (below it).
By their numbers in this assay, from the lowest: compound 4; then compound 3; then compounds 2 and 1 (each within the scatter of the next).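

At the carbonyl carbon on the ring amide-type nitrogen, the series had not reached its lowest number with compound 3 in this assay: adding methyl to the chain gives a 2.1-fold lower number from compound 3 to compound 4 (0.33 log units; beyond the scatter). The 1,1-difluoropropyl also gives an 8.7-fold lower number from compound 2 to compound 4 (0.94 log units; beyond the scatter) and an 11-fold lower number from compound 1 to compound 4 (1.05 log units; beyond the scatter), the largest step among these compounds. Nothing available accounts for these steps.

Open, going by these compounds, is whether a longer chain on the difluorinated carbon, such as butyl, lowers the number further or raises it. Also open, on these data alone, is how a plain propyl chain without fluorine compares.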